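Methoxy to 1H-1,2,4-triazol-1-yl on the shared core

A few compounds are considered here, and "the series" means these few. Any claim that something is new, unique, unknown or untested is made for them only; others in the source may bear on it.

For the measured compounds named here, in a functional assay on SK-OV-3 cells (Homo sapiens) for inhibition, read by CCK-8 assay, with a stated time of 70 h (on this read-out higher numbers stand for weaker inhibition and lower numbers for stronger inhibition), compound 1 `COc1ccc(OCCOCCNC2CCCC2)cc1` gives 99100 nM, the only true number so far. Compound 2 `COC(=O)c1ccccc1COc1ccc(OCCOCCNC2CCCC2)cc1` gives > 100000 nM, which is a limit and not a number.

Compound 3 `c1ncn(-c2ccc(OCCOCCNC3CCCC3)cc2)n1` replaces the methoxy of compound 1: 1H-1,2,4-triazol-1-yl in place of methoxy on an aromatic carbon. Going by the values given here, the one measured step, a number no lower from compound 1 to compound 2 (the limit leaves the size open), also acts on the methoxy, but its size is left open by the limit of > 100000 nM in this assay, at which 1 of the 2 values shown sits. That step offers no size to carry over, so no change beyond the scatter is expected in this assay. The expected step is a 1.4-fold lower number from compound 1 to compound 3 (0.15 log units; within the scatter). The estimate for compound 3 is 70000 nM, with an expected range of 20000 nM to 100000 nM.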

Compound 3, half-maximal inhibitory concentration: > 100000 nM
Compound 3 gave a limit, no number; the forecaster's own chance of this, stated with the estimate: 45%; middle value at least 1.4-fold (0.15 log units) from the limit.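

In this assay compound 3 gives > 100000 nM, a limit and not a number. On this aromatic carbon, 1H-1,2,4-triazol-1-yl in place of methoxy gives a number no lower from compound 1 to compound 3 (the limit leaves the size open), so this change, with its larger five-membered aromatic ring, brings no lower number into view. The size of this step cannot be read, and the limit now holds most of the series: the limit of > 100000 nM in this assay, at which 2 of the 3 values shown sit.

Still open, from the compounds shown here alone, is whether any group at this position gives a clearly lower number than compound 1. An amine or a carboxylic acid on this aromatic carbon would test that.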